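Putting 4-chlorophenyl on compound 3

A few compounds are considered here, and "the series" means these few. Any claim that something is new, unique, unknown or untested is made for them only; others in the source may bear on it.

Values in a functional assay on K562 cells (Homo sapiens) for cytotoxicity, read by ELISA, with a stated time of 4 days (a lower number here means a stronger inhibitor, a higher number a weaker inhibitor), so far:
compound 1 `Cc1ccsc1-c1cc(-c2ccoc2)cc(-c2ccco2)n1` gives 23300 nM
compound 2 `Cc1ccsc1-c1cc(-c2ccoc2)cc(-c2ccc(Cl)cc2)n1` gives 19600 nM
compound 3 `Cc1ccsc1-c1cc(-c2ccc(Cl)o2)cc(-c2ccco2)n1` gives 10600 nM
compound 4 `Cc1ccsc1-c1cc(-c2ccc(Cl)o2)cc(-c2ccc(Cl)cc2)n1` has no value yet

Compound 3 at 10600 nM holds the lowest of the three numbers, but compound 2 at 19600 nM lies within the scatter of it. Only compound 1 stands apart, with a 2.2-fold lower number from compound 1 to compound 3 (0.34 log units; beyond the scatter) as a modest step. Going on to compound 4 puts 4-chlorophenyl in place of furan-2-yl on an aromatic carbon. Among the measured compounds shown here, the one measured step with this same swap is a 1.2-fold lower number from compound 1 to compound 2 (0.08 log units; within the scatter) and it stays within the scatter, although it was taken without the 5-chlorofuran-2-yl group present. The other measured step concerns a different group and says nothing direct about this swap. No step beyond the scatter is therefore expected in this assay, and any drift is expected to be slight and towards a lower number. The estimate means a 1.2-fold lower number from compound 3 to compound 4 (0.07 log units; within the scatter) as the expected step. Compound 4 is estimated at 9000 nM (expected range 4000 nM to 20000 nM).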

Compound 4, half-maximal inhibitory concentration: 15600 nM
Compound 4: middle estimate off by 1.7-fold (0.24 log units), on the low side, within the range that was stated.
By their numbers in this assay, from the lowest: compounds 3, 4, 2 and 1 (each within the scatter of the next, the first and the last beyond it).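

In this assay, with the 5-chlorofuran-2-yl group present, 4-chlorophenyl in place of furan-2-yl on the aromatic carbon next to the ring nitrogen gives a 1.5-fold higher number from compound 3 to compound 4 (0.17 log units; within the scatter), so this change now stays within the scatter on two cores: the same change on two cores in this assay, a 1.2-fold lower number (0.08 log units; within the scatter) from compound 1 to compound 2 and a 1.5-fold higher number (0.17 log units; within the scatter) from compound 3 to compound 4, 1.7-fold (0.24 log units) apart, within the scatter of two such steps

The other change, 5-chlorofuran-2-yl in place of furan-3-yl, gives a 1.3-fold lower number from compound 2 to compound 4 (0.10 log units; within the scatter) with 4-chlorophenyl present, so the step beyond the scatter seen with furan-2-yl at this position does not recur on the second core, although the two steps do not clearly differ: the same change on two cores in this assay, a 2.2-fold lower number (0.34 log units; beyond the scatter) from compound 1 to compound 3 and a 1.3-fold lower number (0.10 log units; within the scatter) from compound 2 to compound 4, 1.7-fold (0.24 log units) apart, within the scatter of two such steps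

Of the four compounds, only compound 1 and compound 3 remain apart beyond the scatter.

The compounds shown carry only aromatic rings at this position. From the compounds shown here alone, how an amine or a carboxylic acid there would read in this assay stays open.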